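This account rests on a few compounds, and the source may have more. Where it says the series, first, only, none or still open, it means among the compounds named here.

Measured compounds:
Compound 1, `CCCCCNC(=O)n1cc(-c2ccccc2)oc1=O`, gives 39 nM in an assay on isolated protein for inhibition of acid ceramidase (Homo sapiens), read by LC-MS, with a stated time of 1 h; on this read-out lower numbers stand for stronger inhibition and higher numbers for weaker inhibition.
Compound 2, `CCOCCNC(=O)n1cc(-c2ccccc2)oc1=O`, gives 2040 nM in this assay.
Compound 3, `COc1ccc(-c2cn(C(=O)NCCCCc3ccccc3)c(=O)o2)cc1`, gives 400 nM in this assay.

Among these three numbers compound 3 stands second highest: its value lies above that of compound 1 and below that of compound 2. Within the data shown here, the only single-change step among the measured compounds is a 52-fold higher number from compound 1 to compound 2 (1.72 log units; beyond the scatter), a change on the chain attached to the amide-type nitrogen, not on the five-membered ring.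

Compound 4, `CN1CCC(c2cn(C(=O)NCCCCc3ccccc3)c(=O)o2)CC1`, has not yet been measured. It differs from compound 3 by 1-methylpiperidin-4-yl in place of 4-methoxyphenyl on an aromatic carbon. Among the measured compounds shown here, no measured step touches the group on that aromatic carbon, so the measured data give no direct guide to this change; the step from compound 1 to compound 2 shows only that this series can move a great deal with one change. With an aromatic ring replaced by a non-aromatic ring, a weakening is expected, so a 3.8-fold higher number from compound 3 to compound 4 (0.57 log units; beyond the scatter) is the estimated step. Compound 4 is therefore expected to give 1500 nM in this assay, within a wide range from 250 nM to 9000 nM.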

Compound 4, half-maximal inhibitory concentration: 1400 nM
Compound 4: the middle estimate sits 1.1-fold (0.03 log units) above what was measured; measured number inside the range.
By their numbers in this assay, from the lowest: compound 1; then compound 3; then compounds 4 and 2 (each within the scatter of the next).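

Among these compounds, this is the first step that touches the group on the aromatic carbon next to the ring oxygen: in this assay, 1-methylpiperidin-4-yl in place of 4-methoxyphenyl gives a 3.5-fold higher number from compound 3 to compound 4 (0.54 log units; beyond the scatter). Inhibition at this position therefore weakens but is not lost when a non-aromatic ring with a nitrogen replaces the aromatic ring, and this step is smaller than the one on the chain, a 52-fold higher number from compound 1 to compound 2 (1.72 log units; beyond the scatter). Nothing measured here bears on the reason for the step.

The step swaps the aromatic ring for a non-aromatic one and also exchanges the methoxy group for a methylated ring nitrogen, so the compounds shown leave open which of these changes matters. A cyclohexyl group or a piperidin-4-yl group without the methyl on this same carbon would help to pull these changes apart.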